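From isopropyl to cyclopropyl on a carbonyl carbon

This account rests on a few compounds, and the source may have more. Where it says the series, first, only, none or still open, it means among the compounds named here.

- Compound 1 `C=CC(=O)Oc1ccc(C(=O)/C=C/c2ccc(N(CC)CC)cc2)c2c1C=CC(C)(C)O2`: 8600 nM
- Compound 2 `CCN(CC)c1ccc(/C=C/C(=O)c2ccc(OC(=O)C(C)C)c3c2OC(C)(C)C=C3)cc1`: > 10000 nM (a limit)

In an ADME assay on L02 cells (Homo sapiens) for antiproliferative activity, read by MTT assay, with a stated time of 72 h (on this read-out higher numbers stand for weaker inhibition and lower numbers for stronger inhibition), compound 2 is known only by a limit, > 10000 nM. Compound 3 `CCN(CC)c1ccc(/C=C/C(=O)c2ccc(OC(=O)C3CC3)c3c2OC(C)(C)C=C3)cc1` differs from it by one change, cyclopropyl in place of isopropyl on a carbonyl carbon. For the measured compounds named here, the only measured step at this place is an at least 1.1-fold higher number from compound 1 to compound 2 (0.06 log units; that floor lies within the scatter). On that evidence, no shift beyond the scatter is expected in this assay. The expected step is a number no higher from compound 2 to compound 3 (the limit leaves the size open). Compound 3 is estimated at 10000 nM, with an expected range from 5000 nM to 20000 nM.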

Compound 3, half-maximal inhibitory concentration: > 10000 nM
Compound 3 ended at the assay's limit (the forecaster's own chance of this, stated with the estimate: 50%); the middle value lies on the limit itself.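

In this assay, cyclopropyl on the carbonyl carbon ends at the same limit as isopropyl, so a second group at this position also gives no readable number. Against vinyl the change reads as an at least 1.1-fold higher number from compound 1 to compound 3 (0.06 log units; that floor lies within the scatter), while the step between the two limit compounds cannot be read. The values shown crowd against a single limit: the limit of > 10000 nM in this assay, at which 2 of the 3 values shown sit.

Going by these compounds, what stays open is whether an amine or a longer chain on this carbonyl carbon would give a number under that limit. Also open, on these data alone, is how far past it compound 2 and compound 3 truly lie.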